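The compounds below may be only part of what the source reports. "The series", "measured", "known", "first", "only" and "open" are said of these compounds alone.

Values in a functional assay on HCT-116 cells (Homo sapiens) for antiproliferative activity, read by MTT assay, with a stated time of 72 h (a higher number here means a weaker inhibitor, a lower number a stronger inhibitor), for the series so far

- compound 1 `O=S1(=O)C=Cc2cccc(Nc3cccc(C(F)(F)F)c3)c21` gives 330 nM
- compound 2 `O=S1(=O)C=Cc2cccc(Nc3cccc(F)c3)c21` gives 1220 nM

Compound 2 holds the higher number of the two, which makes it the weaker inhibitor of this pair. The next compound to test is compound 3 `O=S1(=O)C=Cc2cccc(Nc3ccc(F)c(F)c3)c21`, which differs from compound 2 by fluoro in place of hydrogen on an aromatic carbon.

For the measured compounds named here, no measured step shows this exact change. Going by the values given here, the only step with any bearing is a 3.7-fold higher number from compound 1 to compound 2 (0.57 log units; beyond the scatter) (modest), and it is a different change, fluoro in place of trifluoromethyl on an aromatic carbon. That single step gives a rough scale and only a weak hint of direction, since the number rose there when fluorine was lost. A small move toward a lower number in this assay is therefore expected, probably not beyond the scatter. The estimated change is a 1.4-fold lower number from compound 2 to compound 3 (0.16 log units; within the scatter) and remains an expectation only. For compound 3 the expected value is 850 nM with an estimated range from 350 nM to 2000 nM (not yet measured).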

Compound 3, half-maximal inhibitory concentration: 680 nM
For compound 3 the middle estimate is 1.3-fold (0.10 log units) above the measured one; low and high end bracket the measured number.
By their numbers in this assay, from the lowest: compound 1; then compounds 3 and 2 (each within the scatter of the next).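

In this assay, placing a fluoro on the aromatic carbon that is ortho to a fluoro group and para to a large group gives a 1.8-fold lower number from compound 2 to compound 3 (0.25 log units; within the scatter) and so stays within the usual scatter, which means this carbon takes a fluoro in place of hydrogen with no readable change in antiproliferative activity. For the compounds shown here, the earlier compounds all carry hydrogen at this carbon and differ only in the group at the other substituted site, where a 3.7-fold higher number from compound 1 to compound 2 (0.57 log units; beyond the scatter) remains the only step beyond the scatter, so the series now holds one substituent exchange that registers and one that does not. No further data bear on this result.

Only hydrogen and fluoro are shown at this carbon, so whether a larger or differently built group there, such as methoxy, an amine or a carboxylic acid, would also leave the number within the scatter remains open. Also open, on these data alone, is how a fluoro at this carbon behaves alongside trifluoromethyl in place of the other fluoro, and whether one step at this carbon holds for other substituents on the same ring.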